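A few compounds are considered here, and "the series" means these few. Any claim that something is new, unique, unknown or untested is made for them only; others in the source may bear on it.

In a functional assay on MDA-MB-231 cells (Homo sapiens) for cytotoxicity, read by MTT assay, with a stated time of 48 h (a lower number here means a stronger inhibitor, a higher number a weaker inhibitor), compound 1 `Fc1cccc(-c2nc(Nc3ccccc3)c3ccccc3n2)c1` gives > 50000 nM, which is a limit of the assay and not a number. Within the data shown here, compound 2 `COc1ccc(Nc2nc(-c3cccc(F)c3)nc3ccc(F)cc23)cc1`, with 4-methoxyphenyl on a nitrogen on an aromatic ring, gives 47300 nM, the only true number so far. Compound 3 `COc1ccccc1Nc1nc(-c2cccc(F)c2)nc2ccc(F)cc12`, with 2-methoxyphenyl there instead, gives > 50000 nM, which is again a limit. Compound 3 therefore has no exact place on the scale, and only compound 1 shares that position with it. The picture so far is the limit of > 50000 nM in this assay, at which 2 of the 3 values shown sit, and compound 2 is the one exception.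

The next structure is compound 4 `Fc1cccc(Nc2nc(-c3cccc(F)c3)nc3ccc(F)cc23)c1`, and the change is 3-fluorophenyl in place of 2-methoxyphenyl on a nitrogen on an aromatic ring. In words, 3-fluorophenyl takes the place of 2-methoxyphenyl on a nitrogen on an aromatic ring. Among the measured compounds shown here, no measured step tests this exact swap. The nearest guide is a change at the same place, an at least 1.0-fold higher number from compound 2 to compound 3 (0.02 log units; that floor lies within the scatter). On that basis, no step beyond the scatter is expected in this assay, and another result reported only as a limit is quite possible. The expected step is an at least 1.1-fold lower number from compound 3 to compound 4 (0.04 log units; that floor lies within the scatter). For compound 4 the estimated value is 45000 nM, with an expected range from 20000 nM to 100000 nM.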

Compound 4, half-maximal inhibitory concentration: 47600 nM
Compound 4: the middle estimate sits 1.1-fold (0.02 log units) below what was measured; measured number inside the range.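

In this assay, the ring on the nitrogen can carry a fluorine in place of a methoxy group with no difference beyond the scatter (a 1.0-fold higher number from compound 2 to compound 4 (0.00 log units; within the scatter)). The comparison with the 2-methoxyphenyl compound gives only a floor (an at least 1.0-fold lower number from compound 3 to compound 4 (0.02 log units; that floor lies within the scatter)), and that floor is all it can give, as one end of this step is a limit of the assay and not a number. So the 3-fluorophenyl group brings no clear gain over either methoxyphenyl group, and the readings at this position stay at the weak end of what the assay can report: the limit of > 50000 nM in this assay, at which 2 of the 4 values shown sit.

Still open, on these data alone, is whether any group at this position can bring the number well down, for example an amine, a hydroxyl or a carboxylic acid on the ring in place of the fluorine or methoxy group. The compounds shown also leave open whether 3-fluorophenyl and 4-methoxyphenyl would stay level on a different core, since each comparison here rests on the one shared core.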